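A few compounds are considered here, and "the series" means these few. Any claim that something is new, unique, unknown or untested is made for them only; others in the source may bear on it.

In a functional assay on HT-29 cells (Homo sapiens) for antiproliferative activity, read by MTT assay, with a stated time of 72 h (on this read-out higher numbers stand for weaker inhibition and lower numbers for stronger inhibition), compound 1 `C=C1CC[C@H]2O[C@@]2(C)[C@H](OC(=O)C=C(C)C)/C=C/[C@@](C)(CCC=C(C)C)C[C@H]1O` gives only a limit, > 20000 nM. Within the data shown here, compound 2 `CC(C)=CCC[C@]1(C)/C=C/[C@@H](OC(=O)C=C(C)C)[C@]2(C)O[C@@H]2CC/C(CO)=C\C1` gives 6800 nM, the only actual number so far, which makes it the single measured reference point. Compound 3 `CC(C)=CCC[C@]1(C)/C=C/[C@@H](OC(=O)C=C(C)C)[C@]2(C)O[C@@H]2CC/C(C=O)=C\C1` carries formyl in place of hydroxymethyl on a double-bonded ring carbon. Among the measured compounds shown here, no measured step between close relatives shows what such a change does, so any forecast is uncertain. A modest shift toward stronger inhibition is expected, with an estimated 2.3-fold lower number from compound 2 to compound 3 (0.36 log units; beyond the scatter). For compound 3 the expected value is 3000 nM, with an estimated range of 700 nM to 12000 nM.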

Compound 3, half-maximal inhibitory concentration: 7800 nM
The estimate for compound 3 lay 2.6-fold (0.41 log units) below the measured number; the measured number falls inside the stated range.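

In this assay, the step from hydroxymethyl to formyl on this double-bonded ring carbon is a 1.1-fold higher number from compound 2 to compound 3 (0.06 log units; within the scatter), so compound 2 and compound 3 read alike. The hydroxymethyl group's hydrogen-bond donor is absent from formyl, yet the two numbers stay within the usual scatter of each other. At this position, then, the donor count does not separate these two compounds in this assay. Still open, going by these compounds, is whether a carboxylic acid, an amine or a longer chain on the same carbon would read alike. Nothing available here explains why these two groups give such similar numbers.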